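A Smaller Aryl Amide Replaces the Benzothiazole

A few compounds are considered here, and "the series" means these few. Any claim that something is new, unique, unknown or untested is made for them only; others in the source may bear on it.

Of the compounds shown here, three built on one shared core have been tested in a functional assay on CLL cells (Homo sapiens) for cytotoxicity, read by MTT assay, with a stated time of 48 h; a higher number here means that more compound is needed for the effect, a lower number that less compound is needed. Compound 1 `C=C(CC)C(=O)c1ccc(OCC(=O)Nc2nc3ccccc3s2)c(Cl)c1Cl` gives 1500 nM, the lowest of the three numbers. Compound 2 `C=C(CC)C(=O)c1ccc(OCC(=O)Nc2ccc3cc(C(=O)O)ccc3c2)c(Cl)c1Cl` gives 3700 nM, a gap beyond the usual scatter, and compound 3 `C=C(CC)C(=O)c1ccc(OCC(=O)Nc2ccc3c(c2)C(O)N=NC3O)c(Cl)c1Cl` gives 8500 nM, the number furthest from compound 1. No two of these compounds differ in only one place, so no single step can be read from them. Compound 4 `C=C(CC)C(=O)c1ccc(OCC(=O)Nc2ccc(C#N)cc2)c(Cl)c1Cl` is not yet measured. It differs from compound 1 as follows: 4-cyanophenyl in place of 1,3-benzothiazol-2-yl on an amide-type nitrogen. With 4-cyanophenyl in place of 1,3-benzothiazol-2-yl, the step of a 1.7-fold higher number from compound 1 to compound 4 (0.22 log units; within the scatter) is expected to be a modest rise, near the edge of the scatter. Compound 4 is therefore estimated at 2500 nM, with a likely range from 800 nM to 8000 nM.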

Compound 4, half-maximal effective concentration: 7800 nM
Beside the measured number, compound 4's estimate is 3.1-fold (0.49 log units) below it; measured number inside the range.
By their numbers in this assay, from the lowest: compound 1; then compound 2; then compounds 4 and 3 (each within the scatter of the next).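

In this assay, among these compounds, 4-cyanophenyl in place of 1,3-benzothiazol-2-yl gives a 5.2-fold higher number from compound 1 to compound 4 (0.72 log units; beyond the scatter), the first single change that can be read. It shows that the group on the amide-type nitrogen matters at this position, and that 4-cyanophenyl does not match 1,3-benzothiazol-2-yl here. No evidence is available that explains this rise. Still open, going by these compounds, is whether an amine or a methoxy group in place of the nitrile would bring the number back towards that of compound 1.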